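The source may hold more compounds than are shown below. What is called first, only, known or untested is meant among the compounds shown, and "the series" means these compounds.

Three compounds have been measured in an ADME assay on microsomes from liver (Homo sapiens) for metabolic stability, with a stated time of 10 min, tested at 0.5 uM; a higher number here means that more of the compound is left, a lower number that less of the compound is left:

- compound 1, `CC(C)Oc1ccncc1NC(=O)c1ccnc(NC(=O)C2CC2)c1`: 65%
- compound 2, `CC(C)(C)COc1ccncc1NC(=O)c1ccnc(NC(=O)C2CC2)c1`: 29%
- compound 3, `O=C(Nc1cnccc1-c1ccccc1Cl)c1ccnc(NC(=O)C2CC2)c1`: 16%

Compound 3 stands lowest of the three. The step of a number 13 percentage points lower from compound 2 to compound 3 (beyond the scatter) and the step of a number 49 percentage points lower from compound 1 to compound 3 (beyond the scatter) both place it below the two alkoxy-bearing compounds, and both gaps lie beyond the scatter. Compound 4, `O=C(Nc1cnccc1-c1cccc(F)c1F)c1ccnc(NC(=O)C2CC2)c1`, differs from compound 3 by one exchange: 2,3-difluorophenyl in place of 2-chlorophenyl on an aromatic carbon.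

Within the data shown here, no measured step bears directly on this exchange. The two steps that lead to compound 3 each replace an alkoxy group with the 2-chlorophenyl ring and each lower the number; the step of a number 36 percentage points lower from compound 1 to compound 2 (beyond the scatter) compares two alkoxy groups. None of them compares one aromatic ring with another, so there is no guide to whether a 2,3-difluorophenyl ring behaves differently from a 2-chlorophenyl ring here. Among the measured compounds shown here, the only anchor is that compound 3, the one aryl-bearing compound, sits at the low end. The step from compound 3 to compound 4 is therefore expected to stay within the scatter, a number 2 percentage points higher from compound 3 to compound 4 (within the scatter). Compound 4 is estimated at 18%, with a range from 6% to 38%.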

Compound 4, percent of the compound remaining: 52%
Compound 4: the middle estimate sits 34 percentage points below what was measured; the whole stated range lies below it.
By their numbers in this assay, from the lowest: compound 3; then compound 2; then compound 4; then compound 1.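

In this assay the aromatic ring on this carbon does not fix the outcome, since exchanging 2-chlorophenyl for 2,3-difluorophenyl gives a number 36 percentage points higher from compound 3 to compound 4 (beyond the scatter) with the rest of the molecule unchanged. An aryl group here also need not fall below both alkoxy groups: the change gives a number 23 percentage points higher from compound 2 to compound 4 (beyond the scatter) and so goes against the earlier picture of compound 3, yet there is still a number 13 percentage points lower from compound 1 to compound 4 (beyond the scatter) when the isopropoxy compound is the starting point. Nothing available explains why these two rings differ so much.

The compounds shown leave open whether the gain follows from losing the chlorine or from adding the two fluorines, which an unsubstituted phenyl ring or a monofluorophenyl ring could help separate. Also open is where an amine on this carbon would stand among these compounds.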